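Urea to pivalamide and back, with nitrogen methylation

The source may report more compounds than this note shows. Statements on the series, on what has been measured and on what is new or still open speak of the compounds shown alone.

Measured so far in an assay on COS-7 cells for inhibition of patatin-like phospholipase domain-containing protein 2 (Mus musculus), tested at 200 uM; on this read-out lower numbers stand for less inhibition and higher numbers for more inhibition at the one concentration tested (going by the name of the read-out):
compound 1 `CN(C)C(=O)Nc1cccc(-c2ccc(N(C)C)cc2)c1` gives 98%
compound 2 `CN(C)c1ccc(-c2cccc(NC(=O)C(C)(C)C)c2)cc1` gives 25%

Among the compounds with values here, compound 2 stands lowest of the two numbers known; its nearest neighbour is compound 1, which sits higher by a number 73 percentage points lower from compound 1 to compound 2 (beyond the scatter) when read backwards. That single step, tert-butyl in place of dimethylamino on a carbonyl carbon, is the only one measured, and it is large.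

Compound 3 `CN(C)C(=O)N(C)c1cccc(-c2ccc(N(C)C)cc2)c1` is the next candidate for this assay. Its change from compound 2 is (dimethylcarbamoyl)(methyl)amino in place of ((tert-butyl)carbonyl)amino on an aromatic carbon. In effect this undoes the step from compound 1 to compound 2 and adds a methyl on the nitrogen that carries the carbonyl group, so the hydrogen-bond donor counted under the leaving group is gone. The step from compound 1 to compound 2 bears on it directly: reversing that change argues for a rise of about the same size. Within the data shown here, no measured step speaks to the methylation itself, so the range is kept wide.

Compound 3 is therefore expected to show a number 55 percentage points higher from compound 2 to compound 3 (beyond the scatter), landing at an estimated 80% (range 45% to 98%).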

Compound 3, a percentage reported as inhibition, at one concentration (the size of the read-out at that concentration, not a potency): 74%
Compound 3: the middle estimate sits 6 percentage points above what was measured, and the stated range covers the measured number.
By their numbers in this assay, from the lowest: compound 2; then compound 3; then compound 1.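

In this assay, within the data shown here, the step of a number 24 percentage points lower from compound 1 to compound 3 (beyond the scatter) gives the first separate reading of methyl in place of hydrogen on the amide-type nitrogen: it lies beyond the scatter, but it is modest. The step of a number 49 percentage points higher from compound 2 to compound 3 (beyond the scatter) is large, even though the entering (dimethylcarbamoyl)(methyl)amino carries no hydrogen-bond donor and the leaving ((tert-butyl)carbonyl)amino carries one, so across compound 1, compound 2 and compound 3 the read-out does not follow the presence of that donor: compound 1 and compound 2 both have it and compound 3 lacks it, yet compound 2 gives the lowest number. Nothing available accounts for either step.

Still open, on these data alone, is how the number in this assay changes with further changes to the urea, for example ethyl in place of the added methyl on the nitrogen, or a pyrrolidine ring in place of the dimethylamino group on the carbonyl. Also open is whether the methylated urea holds its read-out when a carboxylic acid replaces the dimethylamino group elsewhere on the core, and a single tested concentration gives no potency for any of these compounds.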